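A Methylsulfonyl in Place of Fluoro on a Weak Amide

A few compounds are considered here, and "the series" means these few. Any claim that something is new, unique, unknown or untested is made for them only; others in the source may bear on it.

Compound 1 `O=C(Nc1ccc(Cl)c(-c2nnc3c(Cl)cccn23)c1)c1ccc(F)cc1Cl` was tested in a functional assay on HeLa cells (Homo sapiens) for antiproliferative activity, read by MTT assay, with a stated time of 72 h; a higher number here means a weaker inhibitor, a lower number a stronger inhibitor. In this assay compound 1 reaches only the limit of > 100000 nM, so no number is known for it. Its two measured neighbours change the group on the carbonyl carbon. Compound 2 `Cc1nc(C(=O)Nc2ccc(Cl)c(-c3nnc4c(Cl)cccn34)c2)cs1` gives 79800 nM in this assay. Compound 3 `O=C(Nc1ccc(Cl)c(-c2nnc3c(Cl)cccn23)c1)c1cccnc1` gives only the limit of > 100000 nM in this assay. The step of an at least 1.2-fold lower number from compound 1 to compound 2 (0.09 log units; that floor lies within the scatter) and the step of an at least 1.2-fold higher number from compound 2 to compound 3 (0.09 log units; that floor lies within the scatter) are both floors that lie within the scatter, and the step that the two limits leave unreadable from compound 1 to compound 3 cannot be read at all because of the limit of > 100000 nM in this assay, at which 2 of the 3 values shown sit.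

Compound 4 `CS(=O)(=O)c1ccc(C(=O)Nc2ccc(Cl)c(-c3nnc4c(Cl)cccn34)c2)c(Cl)c1` differs from compound 1 in one place: methylsulfonyl in place of fluoro on an aromatic carbon. Going by the values given here, none of the measured steps touches this group; all three swap the whole ring on the carbonyl carbon, and none of them is read as beyond the scatter. A step of a number no higher from compound 1 to compound 4 (the limit leaves the size open) is therefore expected, which stays within the scatter of a compound that itself sits at a limit. Compound 4 is estimated at 100000 nM in this assay, with a range from 30000 nM to 300000 nM, and it is thought likely that this assay again reports only a limit.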

Compound 4, half-maximal inhibitory concentration: > 100000 nM
Compound 4: a limit, no number; the forecaster's own chance of this, stated with the estimate: 60%; the middle value lies on the limit itself.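

No step can be read between compound 1 and compound 4, because in this assay both compounds stop at a limit and neither gives a number: the limit of > 100000 nM in this assay, at which 3 of the 4 values shown sit.

The compounds shown leave open whether methylsulfonyl in place of fluoro on an aromatic carbon changes antiproliferative activity at all, and how far either compound lies beyond that limit.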